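Chlorine removal on the aryl group of compound 1

The source may report more compounds than this note shows. Statements on the series, on what has been measured and on what is new or still open speak of the compounds shown alone.

Compound 1 `CCOC(=O)C(C(=O)OCC)C(CC(=O)C[C@@H]1O[C@H](CO)[C@@H](O)[C@H](O)[C@H]1O)c1ccc(Cl)cc1` is a C-glycoside carrying a diethyl malonate arm and a 4-chlorophenyl group. In an assay for inhibition of glucose-6-phosphatase catalytic subunit 1 (Rattus norvegicus), tested at 100 uM (a lower number here means less inhibition, a higher number more inhibition at the concentration tested (going by the name of the read-out)), compound 1 gives -6%. The two other members recorded alongside it are compound 2 `O=C(/C=C/c1ccc2ccccc2c1)C[C@@H]1O[C@H](CO)[C@@H](O[C@@H]2O[C@H](CO)[C@@H](O)[C@H](O)[C@H]2O)[C@H](O)[C@H]1O`, a disaccharide enone, which in this assay gives -3.9%, and compound 3 `O=C(/C=C/c1cccnc1)C[C@@H]1O[C@H](CO)[C@@H](O)[C@H](O)[C@H]1O`, a pyridyl enone, which in this assay gives -8.1%. All three numbers sit within the usual scatter of one another; compound 1 lies between them, with compound 3 nearest and compound 2 furthest, both gaps inside the scatter. None of the three shows inhibition that can be separated from noise at the concentration tested.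

Compound 4 `CCOC(=O)C(C(=O)OCC)C(CC(=O)C[C@@H]1O[C@H](CO)[C@@H](O)[C@H](O)[C@H]1O)c1ccccc1` differs from compound 1 by hydrogen in place of chloro on an aromatic carbon. Within the data shown here, no measured pair in this set isolates that change, so the expectation rests only on the flat numbers seen so far. The step from compound 1 to compound 4 is expected to be a number 1 percentage points higher from compound 1 to compound 4 (within the scatter), that is, no movement beyond the scatter. Compound 4 is therefore estimated at -5%, within a range of -16% to 6%.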

Compound 4, a percentage reported as inhibition, at one concentration (the size of the read-out at that concentration, not a potency): -3.3%
Estimate against measurement, compound 4: 1.7 percentage points below, within the range that was stated.
By their numbers in this assay, from the lowest: compounds 3, 1, 2 and 4 (each within the scatter of the next).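

Among these compounds, replacing 4-chlorophenyl with phenyl gives the first comparison that differs in one place, and this assay reads a number 2.7 percentage points higher from compound 1 to compound 4 (within the scatter) for this change. On this single pair, chloro and hydrogen on this aromatic carbon cannot be told apart at the concentration tested, and neither compound shows inhibition separable from noise, so the chloro group is not seen to contribute here. No supporting evidence bears on this step.

With both compounds flat, this pair cannot show whether the position would matter in a compound with real inhibition. From the compounds shown here alone, what an amine or a methoxy group would do at this place stays open, as does the effect of a carboxylic acid in place of the ethyl esters of the diethyl malonate arm.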